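A few compounds are considered here, and "the series" means these few. Any claim that something is new, unique, unknown or untested is made for them only; others in the source may bear on it.

Measured compounds:
- Compound 1 `O=C(O)CCC(=O)N1N=C(c2c(-c3ccc(Br)cc3)c3ccccc3[nH]c2=O)CC1c1ccc(Cl)cc1`; in an assay on cells (Oocyte) for negative allosteric modulation of glutamate receptor ionotropic, NMDA 2D (Rattus norvegicus), read by two-electrode voltage clamp (a lower number here means a stronger inhibitor, a higher number a weaker inhibitor), compound 1 gives 290 nM
- Compound 2 `COc1ccc(-c2c(C3=NN(C(=O)CCC(=O)O)C(c4ccc(Cl)cc4)C3)c(=O)[nH]c3ccccc23)cc1`; in this assay compound 2 gives 2300 nM
- Compound 3 `O=C(O)CCC(=O)N1N=C(c2c(-c3ccc(C(F)(F)F)cc3)c3ccccc3[nH]c2=O)CC1c1ccc(Cl)cc1`; in this assay compound 3 gives 2800 nM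

Compound 3 has the highest number of the three. Its nearest neighbour is compound 2, the pair differing by a 1.2-fold higher number from compound 2 to compound 3 (0.09 log units; within the scatter), which is within the scatter. Its furthest is compound 1, from which it is separated by a 9.7-fold higher number from compound 1 to compound 3 (0.98 log units; beyond the scatter); the parallel change to compound 2 gave a 7.9-fold higher number from compound 1 to compound 2 (0.90 log units; beyond the scatter).

Compound 4 `O=C(O)CCC(=O)N1N=C(c2c(-c3ccc(F)c(Cl)c3)c3ccccc3[nH]c2=O)CC1c1ccc(Cl)cc1` differs from compound 3 in one place: 3-chloro-4-fluorophenyl in place of 4-(trifluoromethyl)phenyl on an aromatic carbon.

Going by the values given here, no measured step covers this exact exchange. Among the compounds with values here, the steps that bear on it both concern the same ring on the shared core: exchanging the bromo for methoxy or for trifluoromethyl raised the number, by a 7.9-fold higher number from compound 1 to compound 2 (0.90 log units; beyond the scatter) and by a 9.7-fold higher number from compound 1 to compound 3 (0.98 log units; beyond the scatter), so the substitution pattern on this ring moves the read-out. Compound 4 carries two halogens on that ring, closer in kind to compound 1 than to compound 3. In this assay compound 4 is therefore expected to return toward the number of compound 1, with the step of a 4.7-fold lower number from compound 3 to compound 4 (0.67 log units; beyond the scatter) estimated, though the unmeasured pattern leaves the size uncertain. The estimate for compound 4 is 600 nM, within 200 nM to 2000 nM.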

Compound 4, half-maximal inhibitory concentration: 1000 nM
Compound 4: middle estimate off by 1.7-fold (0.22 log units), on the low side, and the stated range covers the measured number.
By their numbers in this assay, from the lowest: compound 1; then compound 4; then compounds 2 and 3 (each within the scatter of the next).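

Working notes on the aryl position of the shared core, in this assay: 3-chloro-4-fluorophenyl gives a lower number than 4-(trifluoromethyl)phenyl (a 2.8-fold lower number from compound 3 to compound 4 (0.45 log units; beyond the scatter)) and than 4-methoxyphenyl (a 2.3-fold lower number from compound 2 to compound 4 (0.36 log units; beyond the scatter)), but a higher number than 4-bromophenyl (a 3.4-fold higher number from compound 1 to compound 4 (0.54 log units; beyond the scatter)). The earlier compounds showed only compound 1 set apart from a pair within the scatter of each other, whereas compound 4 lies beyond the scatter from all three, so this position resolves an intermediate level, and among these four compounds a ring bearing halogens alone does not reproduce the number of compound 1. Nothing available on these compounds accounts for the differences between these aryl groups.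

The compounds shown leave open whether the chloro or the fluoro of compound 4 sets its number, since a ring carrying only one of these two halogens is not among them. They also leave open how an amine or a nitrile on this ring would compare with the bromo of compound 1.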